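Swapping a Methyl for Methoxy on a Weak Inhibitor

The compounds below may be only part of what the source reports. "The series", "measured", "known", "first", "only" and "open" are said of these compounds alone.

Of the compounds shown here, three that share one core have been measured in an ADME assay on isolated protein for inhibition of Amine oxidase [flavin-containing] B (Homo sapiens); on this read-out higher numbers stand for weaker inhibition and lower numbers for stronger inhibition. Compound 1 `C#CCNC1CCc2c(SCc3cccc(C)c3)cccc21` gives > 100000 nM in this assay; that value is a limit of the assay rather than a number, so compound 1 stands at the limit of > 100000 nM in this assay, at which 1 of the 3 values shown sits. Compound 3 `C#CCNC1CCc2c(SCc3ccc(C)cc3)cccc21`, in which 4-methylphenyl replaces 3-methylphenyl on a saturated chain carbon bound to a sulfur, gives 320 nM in this assay. Compound 2 `C#CCNC1CCc2c(SCCc3ccc(C)cc3)cccc21`, whose chain to the ring is longer, gives 4520 nM in this assay. Within the data shown here, the only step that starts from compound 1 is an at least 310-fold lower number from compound 1 to compound 3 (2.49 log units; beyond the scatter); it moves the methyl to another place on the ring rather than exchanging it for a different group.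

Compound 4 `C#CCNC1CCc2c(SCc3cccc(OC)c3)cccc21` has not been measured. It differs from compound 1 by methoxy in place of methyl on an aromatic carbon. Among the measured compounds shown here, no measured step exchanges a methyl for a methoxy, and none keeps the group at the place it occupies in compound 1. The step to compound 3 shows how strongly the placement of the group can matter, but it gives no guide to what a methoxy at the same place does. For the measured compounds named here, with compound 1 at the limit and no step to rest on, compound 4 is expected to remain close to it, and the estimated step is a number no higher from compound 1 to compound 4 (the limit leaves the size open). Compound 4 is therefore estimated at 100000 nM, with a range from 20000 nM to 300000 nM, and a real chance that only a limit is reported again.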

Compound 4, half-maximal inhibitory concentration: 1520 nM
Estimate against measurement, compound 4: 66-fold (1.82 log units) above; measured number outside the range, below it.
By their numbers in this assay, from the lowest: compound 3; then compound 4; then compound 2. At a limit, above all of these: compound 1.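

In this assay, the place held by the methyl in compound 1 turns out not to be closed to inhibition, since changing only the group there, and not its place, gives an at least 65-fold lower number from compound 1 to compound 4 (1.81 log units; beyond the scatter). The earlier step, an at least 310-fold lower number from compound 1 to compound 3 (2.49 log units; beyond the scatter), moved the methyl and so tied the difference to where the group sits; this new step shows that which group sits at the original place matters as well, and that a change of a single heavy atom's worth of size, with one added hydrogen-bond acceptor, can be enough. Compound 1 is a limit of the assay and not a number, so the step has a known lower bound but no known full size: the limit of > 100000 nM in this assay, at which 1 of the 4 values shown sits.

As far as these compounds go, only methyl and methoxy appear at this place, so it remains open whether the oxygen of the methoxy matters or whether an ethyl, with the same count of heavy atoms but no oxygen, would do the same, and a hydroxyl or a chlorine atom there would help to separate these readings. From the compounds shown here alone, it also remains open what a methoxy would do at the place where compound 3 carries its methyl, or on the longer chain of compound 2.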